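The compounds below may be only part of what the source reports. "The series", "measured", "known", "first", "only" and "open" are said of these compounds alone.

Compound 1, `CCSCCC12CCC(c3nnc(-c4ccccc4C(F)(F)F)n3C)(CC1)CC2`, gives 72% in a functional assay on the whole organism (strain ICR) for inhibition, with Mus musculus as the target, with a stated time of 16 h, at a dose of 10 mg/kg by the oral route (on this read-out lower numbers stand for less inhibition and higher numbers for more inhibition at the one dose given (going by the name of the read-out)), the higher of the two numbers recorded there. Going by the values given here, compound 2, `CCS(=O)(=O)CCC12CCC(c3nnc(-c4ccccc4C)n3C)(CC1)CC2`, gives 30% in this assay, a gap beyond the scatter, though the two structures differ in more than one place and no single step between them is defined. Compound 3, `Cn1c(-c2ccccc2C(F)(F)F)nnc1C12CCC(CCCC(C)(F)F)(CC1)CC2`, is not yet measured; it differs from compound 1 by 2,2-difluoropropyl in place of ethylsulfanyl on a saturated chain carbon, two bonds along the chain from a saturated ring carbon. Without a measured step of this kind, the expected step of a number 12 percentage points lower from compound 1 to compound 3 (beyond the scatter) is a small one, within or close to the scatter. Compound 3 is therefore expected to give about 60%, in the range 30% to 85%.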

Compound 3, a percentage reported as inhibition, in the whole organism at one dose (the size of the read-out at that dose, not a potency): 94%
For compound 3 the middle estimate is 34 percentage points below the measured one, and the stated range ends below it.
By their numbers in this assay, from the lowest: compound 2; then compound 1; then compound 3.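

Going by these compounds alone, at this place, on a saturated chain carbon, two bonds along the chain from a saturated ring carbon, the change to 2,2-difluoropropyl from ethylsulfanyl gives the first single-place step in this assay: a number 22 percentage points higher from compound 1 to compound 3 (beyond the scatter). Compound 3 thus shows that the sulfur of ethylsulfanyl is not needed for inhibition at this dose. Nothing available explains the size of this step.

On these data alone, whether the step goes with the fluorine atoms or with the longer chain stays open. A plain propyl group, an amine or a carboxylic acid at this place is not among the compounds shown.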